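Compound 3 to Compound 4: Iodo Gives Way to Methoxy

The compounds below may be only part of what the source reports. "The series", "measured", "known", "first", "only" and "open" are said of these compounds alone.

Among the measured compounds shown here, three compounds share one core and differ only in the single group on their aromatic ring: compound 1 `O=C(Nc1cccc(F)c1)C(Cl)Cl` carries fluoro, compound 2 `O=C(Nc1cccc(Cl)c1)C(Cl)Cl` chloro, and compound 3 `O=C(Nc1cccc(I)c1)C(Cl)Cl` iodo. For the measured compounds named here, in a functional assay on KB cells (Homo sapiens) for antiproliferative activity, read by MTT assay, with a stated time of 72 h (a higher number here means a weaker inhibitor, a lower number a stronger inhibitor), compound 3 gives 5250 nM; compound 1 shows "not determined" (no result reported) and compound 2 shows "not determined" (no result reported), so compound 3 stands alone as the only measured member of the set. Compound 4 `COc1cccc(NC(=O)C(Cl)Cl)c1` brings a new change: methoxy in place of iodo on an aromatic carbon. Going by the values given here, no measured pair shows what this exchange does in this assay, so size and direction of the step are open; a modest shift either way would not surprise, and nothing seen so far argues for a change beyond the scatter. Compound 4 is therefore expected near the same level, at 8000 nM, within 2500 nM to 25000 nM. The expected step is a 1.5-fold higher number from compound 3 to compound 4 (0.18 log units; within the scatter).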

Compound 4, half-maximal inhibitory concentration: 57700 nM
Beside the measured number, compound 4's estimate is 7.2-fold (0.86 log units) below it, outside the stated range (above it).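

In this assay, this place on the aromatic ring proves sensitive to what it carries: methoxy in place of iodo gives an 11-fold higher number from compound 3 to compound 4 (1.04 log units; beyond the scatter). One exchange on the shared core, with every other part of the molecule unchanged, is therefore enough to leave a much weaker inhibitor. Nothing available here explains why the number rises. Going by these compounds, what remains open is whether the loss follows from the arrival of methoxy or the departure of iodo. An amine or a longer chain such as ethoxy at this place could help separate the two.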